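Halogenated aryl group replaces the acetamidophenyl of compound 3

A few compounds are considered here, and "the series" means these few. Any claim that something is new, unique, unknown or untested is made for them only; others in the source may bear on it.

Compound 3 `CC(=O)Nc1ccc(-n2nncc2CN2C(=O)C3(C(C#N)=C(N)Oc4c(N)cc5nc6ccccc6nc5c43)c3ccccc32)cc1` was tested in a functional assay on A549 cells (Homo sapiens) for antiproliferative activity, read by MTT assay, with a stated time of 48 h; a lower number here means a stronger inhibitor, a higher number a weaker inhibitor. In this assay compound 3 gives only > 50000 nM, which is a limit of the assay and not a number. Compound 1 `Cc1ccc(-n2nncc2CN2C(=O)C3(C(C#N)=C(N)Oc4c3c3nc5ccccc5nc3c3ccccc43)c3ccccc32)cc1C` likewise gives only the limit > 50000 nM. Compound 2 `N#CC1=C(N)Oc2c(c3nc4ccccc4nc3c3ccccc23)C12C(=O)N(Cc1cnnn1-c1cc(Cl)ccc1Cl)c1ccccc12` also gives only the limit > 50000 nM. Every value shown so far is a limit, because of the limit of > 50000 nM in this assay, at which 3 of the 3 values shown sit. Compound 4 `N#CC1=C(N)Oc2c(N)cc3nc4ccccc4nc3c2C12C(=O)N(Cc1cnnn1-c1ccc(F)c(Cl)c1)c1ccccc12` differs from compound 3 in one place: 3-chloro-4-fluorophenyl in place of 4-acetamidophenyl on an aromatic nitrogen. Within the data shown here, the single measured one-place change, a step that the two limits leave unreadable from compound 1 to compound 2, gives no readable size, so no measured step tells how large the change to compound 4 might be. Compound 4 is therefore expected to stay at the limit, estimated at 60000 nM, from 20000 nM to 200000 nM, a step that the limit leaves unreadable from compound 3 to compound 4.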

Compound 4, half-maximal inhibitory concentration: 43400 nM
For compound 4 the middle estimate is 1.4-fold (0.14 log units) above the measured one, within the range that was stated.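

In this assay, among these compounds, compound 4 is the first compound here to give a measured number, showing that 3-chloro-4-fluorophenyl on this aromatic nitrogen brings the value inside the readable range. The change gives an at least 1.1-fold lower number from compound 3 to compound 4 (0.06 log units; that floor lies within the scatter), so no real gain in strength can be claimed. Most values shown remain limits of the assay: the limit of > 50000 nM in this assay, at which 3 of the 4 values shown sit.

On these data alone, whether a plain phenyl or an aminophenyl group on this nitrogen would move the number further stays open. Also open, as far as these compounds go, is whether the chlorine or the fluorine matters more, since both enter together.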